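A few compounds are considered here, and "the series" means these few. Any claim that something is new, unique, unknown or untested is made for them only; others in the source may bear on it.

Working notes on a small series sharing one core, examined in an ADME assay on HepG2 2.2.15 cells (Homo sapiens) for cytotoxicity, read by MTT assay, with stated times of 48 h and 9 days; a higher number here means that more compound is tolerated, a lower number that less compound is tolerated. Compound 1 `COc1ccc2c(=O)c(/C=C/C(=O)Nc3ccc(Cl)cc3)coc2c1` gives 272000 nM. Compound 2 `COc1ccc(CNC(=O)/C=C/c2coc3cc(OC)ccc3c2=O)cc1` gives 43000 nM, and compound 3 `COc1ccc(CNC(=O)/C=C/c2coc3cc(O)ccc3c2=O)cc1` gives 718000 nM. Compound 2 therefore stands lowest of the three numbers: the step of a 6.3-fold lower number from compound 1 to compound 2 (0.80 log units; beyond the scatter) and the step of a 17-fold higher number from compound 2 to compound 3 (1.22 log units; beyond the scatter) both leave it at the bottom, the nearer neighbour being compound 1.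

Compound 4 `COc1ccc2c(=O)c(/C=C/C(=O)NCc3ccc(C)cc3)coc2c1` is not yet measured in this assay. It differs from compound 2 in one place: methyl in place of methoxy on an aromatic carbon.

Neither measured step touches the same place. The step from compound 1 to compound 2 alters the whole group on the amide-type nitrogen, and the step from compound 2 to compound 3 removes a methyl from an oxygen on the core, not on the 4-methoxybenzyl ring. The change to compound 4 is smaller than either, a single carbon swapped for a methoxy on the benzyl ring, so a step in this assay at or only just beyond the scatter is expected, with no firm direction; a mild rise is taken as the more likely case, giving an expected 1.5-fold higher number from compound 2 to compound 4 (0.18 log units; within the scatter). For compound 4 the estimate in this assay is 65000 nM, in the range 20000 nM to 220000 nM.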

Compound 4, half-maximal cytotoxic concentration: 257000 nM
Compound 4: middle estimate off by 4.0-fold (0.60 log units), on the low side; the measured number lies above the stated range.
By their numbers in this assay, from the lowest: compound 2; then compounds 4 and 1 (each within the scatter of the next); then compound 3.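

In this assay, within the data shown here, the place on the benzyl ring that no earlier step touched turns out to carry a sizeable effect: with methyl in place of methoxy on the aromatic carbon para to a large group, there is a 6.0-fold higher number from compound 2 to compound 4 (0.78 log units; beyond the scatter). The low number of compound 2 therefore does not belong to the benzyl amide as such, but depends in this pair on the methoxy group. With a 1.1-fold lower number from compound 1 to compound 4 (0.02 log units; within the scatter), the 4-methylbenzyl and 4-chlorophenyl groups on the amide-type nitrogen cannot be told apart in this assay, and no supporting measurement bears on why the methoxy to methyl change has this effect.

Open, as far as these compounds go, is whether other groups at this place, such as hydrogen, chlorine, an amine or a carboxylic acid, stay with compound 4 or move towards compound 2, which would show whether methoxy is the exception. Also open, from the compounds shown here alone, is whether hydrogen in place of methyl on the core oxygen, which gives a 17-fold higher number from compound 2 to compound 3 (1.22 log units; beyond the scatter), has a step of similar size when the 4-methylbenzyl group is present.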